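Changing the aryl group on an amine nitrogen

The source may hold more compounds than are shown below. What is called first, only, known or untested is meant among the compounds shown, and "the series" means these compounds.

Compound 1 `C=C1[C@@H](OC(C)=O)C[C@@H]2[C@](C)(COC=O)[C@H](OC(C)=O)CC[C@@]2(C)[C@@H]1C[C@@H](Nc1ccc(O)cc1)C1=CCOC1=O`: 28900 nM
Compound 2 `C=C1[C@@H](OC(C)=O)C[C@@H]2[C@](C)(CO[Si](C)(C)C(C)(C)C)[C@H](OC(C)=O)CC[C@@]2(C)[C@@H]1C[C@@H](Nc1ccc(F)cc1)C1=CCOC1=O`: 5090 nM
Compound 3 `C=C1[C@@H](OC(C)=O)C[C@@H]2[C@](C)(COC=O)[C@H](OC(C)=O)CC[C@@]2(C)[C@@H]1C[C@@H](Nc1ccccc1C(=O)O)C1=CCOC1=O`: 42500 nM

In a functional assay on KB cells (Homo sapiens) for cytotoxicity, read by sulforhodamine B assay (a higher number here means a weaker inhibitor, a lower number a stronger inhibitor), compound 3 gives 42500 nM, which is within the scatter of compound 1 and a higher number than compound 2. Compound 4 `C=C1[C@@H](OC(C)=O)C[C@@H]2[C@](C)(COC=O)[C@H](OC(C)=O)CC[C@@]2(C)[C@@H]1C[C@@H](Nc1ccc(F)cc1)C1=CCOC1=O` has 4-fluorophenyl in place of 2-carboxyphenyl on an amine nitrogen. Among the measured compounds shown here, the one measured step at this place, a 1.5-fold higher number from compound 1 to compound 3 (0.17 log units; within the scatter), stayed within the scatter, so no large shift is expected. Compound 2 carries the same 4-fluorophenyl group and gives 5090 nM, but it differs from compound 4 elsewhere on the core, so it only tilts the expectation downward. The expected change is a 2.4-fold lower number from compound 3 to compound 4 (0.37 log units; beyond the scatter). For compound 4 the estimated value is 18000 nM, with an expected range of 7000 nM to 45000 nM.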

Compound 4, half-maximal inhibitory concentration: 22900 nM
Estimate against measurement, compound 4: 1.3-fold (0.10 log units) below, and the stated range covers the measured number.
By their numbers in this assay, from the lowest: compound 2; then compounds 4, 1 and 3 (each within the scatter of the next).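

In this assay, with the rest of the molecule unchanged, 4-fluorophenyl on the amine nitrogen stays within the scatter of both other aryl groups (a 1.9-fold lower number from compound 3 to compound 4 (0.27 log units; within the scatter); a 1.3-fold lower number from compound 1 to compound 4 (0.10 log units; within the scatter)). Neither fluoro in place of hydroxy on an aromatic carbon nor the swap for 2-carboxyphenyl clearly moves the number. Among the compounds shown here, the only step here beyond the scatter comes from the change on an oxygen on a saturated carbon (a 4.5-fold higher number from compound 2 to compound 4 (0.65 log units; beyond the scatter)).

Whether an amine or a plain phenyl on the nitrogen would behave alike remains open, and no evidence here explains the step on that oxygen.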